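Extending the side chain on a weak coumarin-triazole inhibitor

This account rests on a few compounds, and the source may have more. Where it says the series, first, only, none or still open, it means among the compounds named here.

Within the data shown here, compound 1, `O=c1cc(Cn2cc(CCCCl)nn2)c2ccc(O)cc2o1`, is the only member of this small set with a numerical result: in a functional assay on CFPAC-1 cells (Homo sapiens) for inhibition, read by MTT assay, with a stated time of 72 h (a lower number here means a stronger inhibitor, a higher number a weaker inhibitor), compound 1 gives 75800 nM. Compound 2, `CC(O)c1cn(Cc2cc(=O)oc3cc(O)ccc23)nn1`, reaches only the limit of the assay, > 100000 nM. Compound 3, `O=c1cc(Cn2cc(-c3cc(F)cc(F)c3)nn2)c2ccc(O)cc2o1`, likewise stops at a limit, > 100000 nM. Both shared the core of compound 1 and changed only the group on the triazole carbon: an at least 1.3-fold higher number from compound 1 to compound 2 (0.12 log units; that floor lies within the scatter), and an at least 1.3-fold higher number from compound 1 to compound 3 (0.12 log units; that floor lies within the scatter). Between the two limits the step that the two limits leave unreadable from compound 2 to compound 3. What the measured values show is mainly (the limit of > 100000 nM in this assay, at which 2 of the 3 values shown sit), so the two changes tried so far did not produce a stronger inhibitor.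

Compound 4, `O=c1cc(Cn2cc(CSC(=S)N3CCOCC3)nn2)c2ccc(O)cc2o1`, also keeps the core of compound 1 and alters the same chain: a group of 9 heavy atoms (5 carbon, 1 nitrogen, 1 oxygen, 2 sulfur; one six-membered non-aromatic ring with 2 hetero atoms) in place of a group of 3 heavy atoms (2 carbon, 1 chlorine; no ring), on a saturated chain carbon bound to an aromatic carbon. The measured steps that bear on it, from compound 1 to compound 2 and from compound 1 to compound 3, both moved to weaker or unreadable values, and neither exceeded the scatter with certainty. A step of similar size or none beyond the scatter is therefore expected in this assay. Compound 4 is expected to give about 80000 nM, within 30000 nM to 200000 nM. This estimate means an expected 1.1-fold higher number from compound 1 to compound 4 (0.02 log units; within the scatter).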

Compound 4, half-maximal inhibitory concentration: 56300 nM
Beside the measured number, compound 4's estimate is 1.4-fold (0.15 log units) above it; the measured number falls inside the stated range.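

This result shows that the position tolerates a much larger group: replacing 2-chloroethyl with a group of 9 heavy atoms that carries a six-membered non-aromatic ring gives a 1.3-fold lower number from compound 1 to compound 4 (0.13 log units; within the scatter). Compound 4 therefore joins compound 1 in giving a number rather than a limit, so a ring and sulfur atoms on this chain do not by themselves push the result out of the measurable range. In this assay, however, compound 1 gives 75800 nM and compound 4 gives 56300 nM, so the two cannot be told apart and this change does not yield a clearly stronger inhibitor.

The steps involving compound 2 and compound 3 that depend on two limits cannot be read, which leaves the comparison across the series coarse: the limit of > 100000 nM in this assay, at which 2 of the 4 values shown sit. As far as these compounds go, it remains open whether the ring or the sulfur atoms of compound 4 matter at all, and whether an amine or a carboxylic acid on a longer chain at this position would move the number beyond the scatter.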